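This account rests on a few compounds, and the source may have more. Where it says the series, first, only, none or still open, it means among the compounds named here.

Measured in a functional assay on MCF7 cells (Homo sapiens) for inhibition, read by MTT assay, with a stated time of 48 h; on this read-out higher numbers stand for weaker inhibition and lower numbers for stronger inhibition:
- Compound 1 `CCCCNC(=O)/C=C/c1c(/C=C/c2ccc(OC)cc2)cc(OC)cc1OC`: 1330 nM
- Compound 2 `COc1ccc(/C=C/c2cc(OC)cc(OC)c2/C=C/C(=O)N2CCC(Cl)CC2)cc1`: 4950 nM
- Compound 3 `COc1ccc(/C=C/c2cc(OC)cc(OC)c2/C=C/C(=O)N2CCC(c3ccccc3)CC2)cc1`: 4230 nM

Compound 3, at 4230 nM, stands level with compound 2 at the weaker end of these numbers. Compound 4 `COc1ccc(/C=C/c2cc(OC)cc(OC)c2/C=C/C(=O)N2CCN(C)CC2)cc1` carries 4-methylpiperazin-1-yl in place of 4-phenylpiperidin-1-yl on a carbonyl carbon.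

Two kinds of measured step bear on this change. Replacing butylamino with a ring gave modest steps: a 3.7-fold higher number from compound 1 to compound 2 (0.57 log units; beyond the scatter) and a 3.2-fold higher number from compound 1 to compound 3 (0.50 log units; beyond the scatter). Changing only the group on that ring gave a 1.2-fold lower number from compound 2 to compound 3 (0.07 log units; within the scatter). Compound 4 keeps a six-membered non-aromatic ring, so the second kind is the closer guide, and no step beyond the scatter is expected in this assay. The expected step is a 1.1-fold lower number from compound 3 to compound 4 (0.02 log units; within the scatter). Going by the values given here, no measured compound carries 4-methylpiperazin-1-yl, so the range stays wide. For compound 4 the estimated value is 4000 nM, with an expected range of 1800 nM to 9000 nM.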

Compound 4, half-maximal inhibitory concentration: 2290 nM
Estimate against measurement, compound 4: 1.7-fold (0.24 log units) above; the range from low to high includes it.
By their numbers in this assay, from the lowest: compounds 1, 4, 3 and 2 (each within the scatter of the next, the first and the last beyond it).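

In this assay, changing the ring group on the carbonyl carbon can shift the number: 4-methylpiperazin-1-yl in place of 4-chloropiperidin-1-yl gives a 2.2-fold lower number from compound 2 to compound 4 (0.33 log units; beyond the scatter) as a step beyond the scatter. Against the other groups the change stays within the scatter, with a 1.8-fold lower number from compound 3 to compound 4 (0.27 log units; within the scatter) and also a 1.7-fold higher number from compound 1 to compound 4 (0.24 log units; within the scatter) on replacing butylamino. A ring on this carbonyl carbon therefore does not always give a number set clearly apart from the butylamino compound.

Nothing shown here explains these differences. Going by these compounds, a morpholine ring, or a piperazine carrying a longer chain, remains open.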